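Compound 4: methyl in place of chloro

This account rests on a few compounds, and the source may have more. Where it says the series, first, only, none or still open, it means among the compounds named here.

Compound 1 `NS(=O)(=O)c1ccc(N2N=C(c3ccccc3)CC2c2ccccc2Cl)cc1` gives 44000 nM
Compound 2 `NS(=O)(=O)c1ccc(N2N=C(c3ccc(OCc4ccccc4)cc3)CC2c2ccccc2Cl)cc1` gives 26000 nM
Compound 3 `NS(=O)(=O)c1ccc(N2N=C(c3ccc(Oc4ccccc4)cc3)CC2c2ccccc2Cl)cc1` gives 40000 nM

These values come from an ADME assay on MT4 cells (Homo sapiens) for cytotoxicity, read by MTT assay, with a stated time of 96 h (on this read-out higher numbers stand for lower toxicity in this test and lower numbers for higher toxicity in this test), and they form a single band. Seen from compound 1, the measured steps are a 1.7-fold lower number from compound 1 to compound 2 (0.23 log units; within the scatter) and a 1.1-fold lower number from compound 1 to compound 3 (0.04 log units; within the scatter) and both lie within the scatter, so compound 1 is not set apart from the other two. The remaining step, a 1.5-fold higher number from compound 2 to compound 3 (0.19 log units; within the scatter), also lies within the scatter.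

Compound 4 `Cc1ccccc1C1CC(c2ccccc2)=NN1c1ccc(S(N)(=O)=O)cc1` has not yet been measured. Its difference from compound 1 is methyl in place of chloro on an aromatic carbon and in short it carries methyl in place of chloro on an aromatic carbon, ortho to a large group. For the measured compounds named here, no measured step alters this chloro, so the evidence is only indirect. The two steps from compound 1 add benzyloxy or phenoxy in place of hydrogen, and neither moves the value beyond the scatter. On that indirect evidence, no step beyond the scatter is expected for this smaller exchange. The expected change is a 1.1-fold lower number from compound 1 to compound 4 (0.04 log units; within the scatter) and this estimate stays within the scatter. For compound 4 the estimate is 40000 nM and the expected range runs from 18000 nM to 85000 nM for a single measurement.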

Compound 4, half-maximal cytotoxic concentration: 43000 nM
For compound 4 the middle estimate is 1.1-fold (0.03 log units) below the measured one, and the stated range covers the measured number.
By their numbers in this assay, from the lowest: compounds 2, 3, 4 and 1 (each within the scatter of the next).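

In this assay, for the compounds shown here, putting methyl in place of chloro on this aromatic carbon, ortho to a large group, gives a 1.0-fold lower number from compound 1 to compound 4 (0.01 log units; within the scatter) and so provides the first direct reading at this position. The earlier steps shown here changed only a hydrogen elsewhere on the molecule, whereas this one shows that the chloro of compound 1 can give way to methyl without a step beyond the scatter, at least for this one exchange of a single heavy atom. Nothing measured here explains why the two groups read alike, and no supporting data bear on this result.

Chloro and methyl both carry no hydrogen-bond donors or acceptors, so the compounds shown leave open whether an amine, a carboxylic acid or a longer chain such as propyl at this position would read the same way. They also leave open whether the hydrogen-bearing parent, without any group at this carbon, would stay within the scatter of compound 1, and whether the 2-chlorophenyl to 2-methylphenyl exchange would read alike on compound 2 or compound 3.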